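This account rests on a few compounds, and the source may have more. Where it says the series, first, only, none or still open, it means among the compounds named here.

In a functional assay on MDA-MB-231 cells (Homo sapiens) for inhibition, read by MTT assay, with a stated time of 72 h (on this read-out lower numbers stand for stronger inhibition and higher numbers for weaker inhibition), compound 1 `O=[N+]([O-])c1cccc(Nc2nnc(-c3c[nH]c4ccccc34)o2)c1` gives 34600 nM and compound 3 `Clc1ccc(Nc2nnc(-c3c[nH]c4ccccc34)o2)cc1Cl` gives 31100 nM while compound 2 `Clc1cccc(Nc2nnc(-c3c[nH]c4ccccc34)o2)c1` gives 8890 nM as the lowest of the three numbers. Compound 4 `c1ccc(CNc2nnc(-c3c[nH]c4ccccc34)o2)cc1` has not been measured and differs from compound 2 in one place: benzyl in place of 3-chlorophenyl on a nitrogen on an aromatic ring with benzyl in place of 3-chlorophenyl on a nitrogen on an aromatic ring. Two modest steps bear on this change: a 3.9-fold lower number from compound 1 to compound 2 (0.59 log units; beyond the scatter) and a 3.5-fold higher number from compound 2 to compound 3 (0.54 log units; beyond the scatter) are the ones available. Both altered a group on the ring that leaves in compound 4, and in both the lower number belongs to compound 2. Neither tests a benzyl group, so they offer only a weak guide. A step of similar size toward a higher number is therefore expected in this assay for this change. The estimated step is a 2.2-fold higher number from compound 2 to compound 4 (0.35 log units; beyond the scatter) on this reasoning. Compound 4 is expected at 20000 nM with 6000 nM to 60000 nM as its estimated range.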

Compound 4, half-maximal inhibitory concentration: 6470 nM
For compound 4 the middle estimate is 3.1-fold (0.49 log units) above the measured one, within the range that was stated.
By their numbers in this assay, from the lowest: compounds 4 and 2 (each within the scatter of the next); then compounds 3 and 1 (each within the scatter of the next).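

In this assay, putting benzyl in place of 3-chlorophenyl on the nitrogen gives a 1.4-fold lower number from compound 2 to compound 4 (0.14 log units; within the scatter), so the two compounds cannot be told apart. The earlier steps shown here altered only groups on the ring, whereas this change replaces the whole 3-chlorophenyl group and the number remains within the scatter of compound 2. Nothing measured here explains this result. Still open, going by these compounds, is how the number would respond to a chloro on the benzyl ring. Also open, on these data alone, is the effect of a longer chain ending in an amine or a carboxylic acid on this nitrogen.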